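Chloro to bromo on the pendant aryl ring: compound 4

A few compounds are considered here, and "the series" means these few. Any claim that something is new, unique, unknown or untested is made for them only; others in the source may bear on it.

Going by the values given here, compound 1 `Cn1ccc2c(Oc3ccc(NC(=O)c4cc5cccnc5n(-c5ccc(Cl)cc5)c4=O)cc3)ncnc21` is the first member of the series; in a functional assay on MCF7 cells (Homo sapiens) for cytotoxicity, read by MTT assay, with a stated time of 72 h (a lower number here means a stronger inhibitor, a higher number a weaker inhibitor), compound 1 gives 95000 nM. Compound 2 `Cn1ccc2c(Oc3ccc(NC(=O)c4cc5cccnc5n(-c5ccc(Br)cc5)c4=O)cc3)ncnc21` differs from it by bromo in place of chloro on an aromatic carbon; in this assay compound 2 gives 79400 nM, a step of a 1.2-fold lower number from compound 1 to compound 2 (0.08 log units; within the scatter). Compound 3 `O=C(Nc1ccc(Oc2ncnc3[nH]ccc23)c(F)c1)c1cc2cccnc2n(-c2ccc(Cl)cc2)c1=O` sits on a second core, and the difference between the two cores is not broken down here. In this assay compound 3 gives 45000 nM. Compound 4 `O=C(Nc1ccc(Oc2ncnc3[nH]ccc23)c(F)c1)c1cc2cccnc2n(-c2ccc(Br)cc2)c1=O` is compound 3 with bromo in place of chloro on an aromatic carbon, the same change as that made from compound 1 to compound 2, at a place described in the same words. Because the earlier step of a 1.2-fold lower number from compound 1 to compound 2 (0.08 log units; within the scatter) lay within the scatter, a like outcome is expected here, and for compound 4 the expected step is a 1.2-fold lower number from compound 3 to compound 4 (0.07 log units; within the scatter). The estimated value of compound 4 in this assay is 38000 nM, between 18000 nM and 80000 nM.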

Compound 4, half-maximal inhibitory concentration: 27000 nM
Compound 4: middle estimate off by 1.4-fold (0.15 log units), on the high side; the measured number falls inside the stated range.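

On the core of compound 3, bromo in place of chloro gives a 1.7-fold lower number from compound 3 to compound 4 (0.22 log units; within the scatter) in this assay. Neither this step nor the earlier one separates bromo from chloro, so the pair shows no effect of the change on either core, and two cores in one assay support no rule for other cores. What can be said is that the change reads alike on both cores: the same change on two cores in this assay, a 1.2-fold lower number (0.08 log units; within the scatter) from compound 1 to compound 2 and a 1.7-fold lower number (0.22 log units; within the scatter) from compound 3 to compound 4, 1.4-fold (0.14 log units) apart, within the scatter of two such steps

Open, as far as these compounds go, is whether an amine, a carboxylic acid or a methoxy group in place of the halogen on the same aromatic carbon would give a step beyond the scatter. Also open, from the compounds shown here alone, is how the parts that differ between the two cores each bear on the numbers.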